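A Fluorinated Pyridine Variant in a Bombesin Receptor Series

This account rests on a few compounds, and the source may have more. Where it says the series, first, only, none or still open, it means among the compounds named here.

Compound 1, `CCC(C)(C)Cc1c[nH]c(CCc2ccc(-c3ccncc3)cc2)n1`, is measured in an in vitro assay on CHO cells for displacement of a labelled ligand from Bombesin receptor subtype-3 (Homo sapiens), read by scintillation counting, with a stated time of 2 h (on this read-out higher numbers stand for weaker inhibition and lower numbers for stronger inhibition), at 101 nM. Of the three compounds measured, compound 1 gives the highest number. Compound 2, `CCC(C)(C)Cc1c[nH]c(CCc2ccc(-c3csnn3)cc2)n1`, gives 45 nM, and compound 3, `CCC(C)(C)Cc1c[nH]c(CCc2ccc(-n3cccn3)cc2)n1`, gives 33 nM. Both carry a five-membered ring in place of the pyridin-4-yl of compound 1: a 2.2-fold lower number from compound 1 to compound 2 (0.35 log units; beyond the scatter) and a 3.1-fold lower number from compound 1 to compound 3 (0.49 log units; beyond the scatter). The unmeasured compound 4, `CCC(C)(C)Cc1c[nH]c(CCc2ccc(-c3ccc(F)cn3)cc2)n1`, differs from compound 1 at the same aromatic carbon, (5-fluoropyridin-2-yl in place of pyridin-4-yl on an aromatic carbon). Within the data shown here, no measured step exchanges one six-membered ring for another, so the two steps from compound 1 bear on it only indirectly: they show that the group on this aromatic carbon can be exchanged with a modest gain, though both of those replacements were five-membered rings rather than a fluorinated pyridine. Compound 4 is therefore expected to show a modest change in this assay, if any beyond the scatter, a 1.4-fold lower number from compound 1 to compound 4 (0.16 log units; within the scatter). The estimate for compound 4 is 70 nM, with an expected range from 30 nM to 200 nM.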

Compound 4, half-maximal inhibitory concentration: 19 nM
Compound 4: middle estimate off by 3.7-fold (0.57 log units), on the high side; measured number below the stated range.
By their numbers in this assay, from the lowest: compounds 4, 3 and 2 (each within the scatter of the next, the first and the last beyond it); then compound 1.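

In this assay, the step to the 5-fluoropyridin-2-yl group, a 5.3-fold lower number from compound 1 to compound 4 (0.73 log units; beyond the scatter), shows that a gain on this aromatic carbon does not require a five-membered ring, since a six-membered aromatic ring with one hetero atom also delivers one. The new group also separates from the 1,2,3-thiadiazol-4-yl group, a 2.4-fold lower number from compound 2 to compound 4 (0.37 log units; beyond the scatter), but not from the 1H-pyrazol-1-yl group, a 1.7-fold lower number from compound 3 to compound 4 (0.24 log units; within the scatter), a step within the scatter that leaves compound 3 and compound 4 unranked. Nothing available here accounts for the difference between the two pyridine groups.

The step from compound 1 to compound 4 changes both the ring's point of attachment and the fluorine, and the compounds shown do not separate the two. A plain pyridin-2-yl group would be needed to tell them apart, and a 5-chloropyridin-2-yl group would show how far this result extends beyond fluorine.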